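The Same Aryl Exchange Tried on a Second Core

This account rests on a few compounds, and the source may have more. Where it says the series, first, only, none or still open, it means among the compounds named here.

Of the compounds shown here, three have been measured so far in a functional assay on MCF7 cells (Homo sapiens) for antiproliferative activity, read by MTT assay, with a stated time of 48 h (a lower number here means a stronger inhibitor, a higher number a weaker inhibitor), and a fourth awaits its number. Compound 1 `COc1ccc(-c2c(Nc3ccc(F)cc3)c3ccccc3oc2=O)cc1` gives 38500 nM. Compound 2 `COc1ccc(-c2c(Nc3ccc(C)c(O)c3)c3ccccc3oc2=O)cc1` gives 12100 nM. For the measured compounds named here, the single change between them is 3-hydroxy-4-methylphenyl in place of 4-fluorophenyl on a nitrogen on an aromatic ring, and in this assay it brought a 3.2-fold lower number from compound 1 to compound 2 (0.50 log units; beyond the scatter).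

Compound 3 `COc1ccc2oc(=O)c(C(=O)C(F)(F)F)c(Nc3ccc(F)cc3)c2c1` is built on a different core, and the difference between the two cores is not broken down here. In this assay compound 3 reaches only a limit of the assay, > 100000 nM. That is the limit of > 100000 nM in this assay, at which 1 of the 3 values shown sits.

Compound 4 `COc1ccc2oc(=O)c(C(=O)C(F)(F)F)c(Nc3ccc(C)c(O)c3)c2c1` stands to compound 3 as compound 2 stands to compound 1: the change is 3-hydroxy-4-methylphenyl in place of 4-fluorophenyl on a nitrogen on an aromatic ring. The place of the change is described in the same words for both pairs, so it is the same change carried onto the second core. Resting on the measured pair, a 3.2-fold lower number from compound 1 to compound 2 (0.50 log units; beyond the scatter), the step from compound 3 to compound 4 in this assay is expected to be of similar size, an at least 1.6-fold lower number from compound 3 to compound 4 (0.22 log units; that floor lies within the scatter). Since the starting point of compound 3 is a limit and not a number, the landing point cannot be fixed tightly. Compound 4 is accordingly estimated at 60000 nM, with an expected range from 20000 nM to 200000 nM, and with a substantial chance that the assay again reports only a limit.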

Compound 4, half-maximal inhibitory concentration: 20100 nM
Beside the measured number, compound 4's estimate is 3.0-fold (0.47 log units) above it; the range from low to high includes it.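

In this assay, 3-hydroxy-4-methylphenyl in place of 4-fluorophenyl on a nitrogen on an aromatic ring brought an at least 4.9-fold lower number from compound 3 to compound 4 (0.69 log units; beyond the scatter), so the change that lowered the number on the core of compound 1 also lowered it on the second core. Set side by side, the two steps read: the same change on two cores in this assay, a 3.2-fold lower number (0.50 log units; beyond the scatter) from compound 1 to compound 2 and an at least 4.9-fold lower number (0.69 log units; beyond the scatter) from compound 3 to compound 4; the limit leaves it open whether they differ

This shows the direction carrying over between these two cores, but the second step remains a floor and not a measured size, and whether the change is worth the same on both cores stays undecided because compound 3 stands at a limit and not at a number: the limit of > 100000 nM in this assay, at which 1 of the 4 values shown sits.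

The compounds shown leave open whether the lower numbers follow the hydroxy group, the methyl group or the two together, since they enter as one 3-hydroxy-4-methylphenyl group, and whether a methoxy group or an amine in place of the hydroxy group would give a step of the same direction. They also leave open whether the change would hold on a third core, for instance one carrying a nitrile or a carboxylic acid.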